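The source may report more compounds than this note shows. Statements on the series, on what has been measured and on what is new or still open speak of the compounds shown alone.

Compound 3, `CCCCCCCCCO[C@@H]1[C@@H](N)[C@@H](OCC(O)CNCCCN)O[C@H](CN)[C@H]1OCCCCCCCCC`, stands highest of the three numbers in a toxicity assay on the whole organism (J774 cells) for cytotoxicity, with Mus musculus as the target, read by MTT assay, with a stated time of 24 h, tested at 30 uM (on this read-out higher numbers stand for a weaker effect at the one concentration tested and lower numbers for a stronger effect), giving 71.6%. Its nearest neighbour is compound 1, `CCCCCCCCCO[C@@H]1[C@@H](N)[C@@H](O[C@H]2[C@H](O)[C@@H](O)[C@H](N)C[C@@H]2N)O[C@H](CN)[C@H]1OCCCCCCCCC`, which in this assay gives 48.6%, separated by the step of a number 23 percentage points higher from compound 1 to compound 3 (beyond the scatter). Furthest away is compound 2, `CCCCCCCCCO[C@@H]1[C@@H](N)[C@@H](OCC(O)CO)O[C@H](CN)[C@H]1OCCCCCCCCC`, which in this assay gives 8.8%, and the step of a number 62.8 percentage points higher from compound 2 to compound 3 (beyond the scatter) is the largest movement seen among these three.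

Compound 4, `CCCCCCCCCO[C@@H]1[C@@H](N)[C@@H](OC[C@H](O)CN)O[C@H](CN)[C@H]1OCCCCCCCCC`, differs from compound 3 in a single place: 2-amino-1-hydroxyethyl in place of 2-((3-aminopropyl)amino)-1-hydroxyethyl on a saturated chain carbon bound to an oxygen on a saturated carbon. The step that bears most directly on this change is a number 62.8 percentage points higher from compound 2 to compound 3 (beyond the scatter), which also concerned the saturated chain carbon two bonds from the oxygen, where a hydroxy was exchanged for the (3-aminopropyl)amino group. Compound 4 keeps an amino group at that carbon but gives up the 3-aminopropyl part, so in structure it sits between compound 2 and compound 3. The step of a number 23 percentage points higher from compound 1 to compound 3 (beyond the scatter) gives a looser second point of reference. A downward move from compound 3 is therefore expected, beyond the scatter, though not a full return to the number of compound 2. The expected step is a number 31.6 percentage points lower from compound 3 to compound 4 (beyond the scatter). Compound 4 is estimated at 40%, within a range from 15% to 65%.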

Compound 4, a percentage reported as activity, at one concentration (the size of the read-out at that concentration, not a potency): 14.4%
The estimate for compound 4 lay 25.6 percentage points above the measured number; measured number outside the range, below it.
By their numbers in this assay, from the lowest: compounds 2 and 4 (each within the scatter of the next); then compound 1; then compound 3.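

In this assay a number 57.2 percentage points lower from compound 3 to compound 4 (beyond the scatter) shows that an amino group on this saturated chain carbon is not enough to keep the high number of compound 3, and that the number goes with the 3-aminopropyl part. The earlier compounds shown here could not separate these two parts, but a number 5.6 percentage points higher from compound 2 to compound 4 (within the scatter) now shows that 2-amino-1-hydroxyethyl in place of 1,2-dihydroxyethyl leaves the number where it was. The a number 34.2 percentage points lower from compound 1 to compound 4 (beyond the scatter) adds that 3-amino-2-hydroxypropyl does not hold the number of compound 1 when it stands in place of 4,6-diamino-2,3-dihydroxycyclohexyl on an oxygen on a saturated carbon, so compound 4 falls with compound 2 on this read-out.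

Still open, as far as these compounds go, is whether a 2-aminoethyl or a 4-aminobutyl group in place of the 3-aminopropyl part would give a number nearer that of compound 3 or that of compound 4. Also open, from the compounds shown here alone, is whether the number depends on the free end amine of that part, which a terminal hydroxy or a terminal dimethylamine would test, and on the defined stereocentre in compound 4.

Nothing shown here gives a measured reason for these differences.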